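This account rests on a few compounds, and the source may have more. Where it says the series, first, only, none or still open, it means among the compounds named here.

Compound 1, `CCc1ccc(NS(=O)(=O)c2ccc(N3CCNC3=O)cc2)cc1`, gives 660 nM in a functional assay on HT-29 cells (Homo sapiens) for antiproliferative activity, read by sulforhodamine B assay, with a stated time of 48 h; a lower number here means a stronger inhibitor, a higher number a weaker inhibitor. Compound 2, `Cc1ccccc1NS(=O)(=O)c1ccc(N2CCNC2=O)cc1`, gives 200 nM in this assay. Compound 3, `O=C1NCCN1c1ccc(S(=O)(=O)Nc2ccc(OC(F)F)cc2)cc1`, gives 650 nM in this assay.

Among these three numbers compound 3 stands second highest. Its nearest neighbour is compound 1, whose number is essentially the same, since the step of a 1.0-fold lower number from compound 1 to compound 3 (0.01 log units; within the scatter) lies within the scatter. Going by the values given here, compound 2 gives a clearly lower number than compound 3, and the one measured step reaching compound 2, a 3.3-fold lower number from compound 1 to compound 2 (0.52 log units; beyond the scatter), swaps the whole substituted ring on the sulfonamide nitrogen rather than a single group on an aromatic carbon.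

Compound 4, `O=C1NCCN1c1ccc(S(=O)(=O)Nc2ccc(I)cc2)cc1`, differs from compound 3 in one place: iodo in place of difluoromethoxy on an aromatic carbon. The step that bears most directly on this change is a 1.0-fold lower number from compound 1 to compound 3 (0.01 log units; within the scatter), where one group on the same aromatic carbon, para to a large group, was exchanged for another without any shift beyond the scatter. On that basis a similar exchange of difluoromethoxy for iodo is expected to move this assay by a 1.1-fold lower number from compound 3 to compound 4 (0.03 log units; within the scatter), that is, no step beyond the scatter. Compound 4 is therefore estimated at 600 nM, with a range from 250 nM to 1500 nM.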

Compound 4, half-maximal inhibitory concentration: 650 nM
Beside the measured number, compound 4's estimate is 1.1-fold (0.03 log units) below it, within the range that was stated.
By their numbers in this assay, from the lowest: compound 2; then compounds 3, 4 and 1 (each within the scatter of the next).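

With iodo in place of difluoromethoxy on an aromatic carbon para to a large group, this assay shows no change at the digits printed from compound 3 to compound 4 (within the scatter), even though 1 heavy atom with 0 hydrogen-bond acceptors replaces 4 heavy atoms with 1 hydrogen-bond acceptor. Adding a 1.0-fold lower number from compound 1 to compound 4 (0.01 log units; within the scatter) gives three different groups at this position, ethyl, difluoromethoxy and iodo, that cannot be told apart in this read-out, while the change of the whole ring on the sulfonamide nitrogen, 4-iodophenyl in place of 2-methylphenyl, gives a 3.3-fold higher number from compound 2 to compound 4 (0.51 log units; beyond the scatter) and so repeats the gap seen with the other two compounds. Nothing among the available data explains why these three groups match or why compound 2 stands apart.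

An amine, a carboxylic acid or a longer chain on this same aromatic carbon would test how far this flat level extends. A 4-methylphenyl on the sulfonamide nitrogen would help separate the effect of the methyl group itself from that of its place in the 2-methylphenyl of compound 2.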